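This account rests on a few compounds, and the source may have more. Where it says the series, first, only, none or still open, it means among the compounds named here.

Measured in a functional assay on HeLa cells (Homo sapiens) for antiproliferative activity, read by MTT assay, with a stated time of 24 h; on this read-out higher numbers stand for weaker inhibition and lower numbers for stronger inhibition:
- compound 1 `COc1ccc(S(=O)(=O)n2c(-c3cn(-c4ccccc4)nc3-c3ccc(C(F)(F)F)cc3)nc3ccccc32)cc1`: 250 nM
- compound 2 `Cc1ccc(C)c(S(=O)(=O)n2c(-c3cn(-c4ccccc4)nc3-c3ccc(C(F)(F)F)cc3)nc3ccccc32)c1`: 210 nM

Compound 2 gives 210 nM and cannot be separated from compound 1 within the scatter. Compound 3 `O=[N+]([O-])c1ccc(S(=O)(=O)n2c(-c3cn(-c4ccccc4)nc3-c3ccc(C(F)(F)F)cc3)nc3ccccc32)cc1` carries 4-nitrophenyl in place of 2,5-dimethylphenyl on a sulfonyl sulfur. Among the compounds with values here, one measured step bears on this place, a 1.2-fold lower number from compound 1 to compound 2 (0.08 log units; within the scatter), with 2,5-dimethylphenyl in place of 4-methoxyphenyl. Within the data shown here, no compound with 4-nitrophenyl has been measured, so this single step is thin evidence, and no shift beyond the scatter is expected in this assay. The expected step is a 1.0-fold higher number from compound 2 to compound 3 (0.02 log units; within the scatter). For compound 3 the estimated value is 220 nM, with an expected range of 90 nM to 550 nM.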

Compound 3, half-maximal inhibitory concentration: 950 nM
Compound 3: the middle estimate sits 4.3-fold (0.64 log units) below what was measured; the measured number lies above the stated range.
By their numbers in this assay, from the lowest: compounds 2 and 1 (each within the scatter of the next); then compound 3.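

In this assay, the aryl group on the sulfonyl sulfur proves able to shift the result, which compound 1 and compound 2 alone had not shown. Moving to 4-nitrophenyl gives a 4.5-fold higher number from compound 2 to compound 3 (0.66 log units; beyond the scatter), and nitro in place of methoxy gives a 3.8-fold higher number from compound 1 to compound 3 (0.58 log units; beyond the scatter), so both steps point to weaker inhibition. Nothing available here explains this shift.

As far as these compounds go, it remains open whether an amine or a carboxylic acid in place of the nitro group would give a similar number. From the compounds shown here alone, it is also open how a plain phenyl on the sulfonyl sulfur would compare.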